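The source may hold more compounds than are shown below. What is called first, only, known or untested is meant among the compounds shown, and "the series" means these compounds.

For the measured compounds named here, compound 1 `CC(/N=c1\c(O)c(O)\c1=N/c1cnc2ccccc2c1)C(C)(C)C` is the first of the three measured compounds. In a functional assay for inhibition, with Rattus norvegicus as the target (a lower number here means a stronger inhibitor, a higher number a weaker inhibitor), compound 1 gives only a limit, > 30000 nM, not a number.
Compound 2 `C[C@@H](/N=c1\c(O)c(O)\c1=N/c1ccc2c[nH]nc2c1)C(C)(C)C` in this assay gives 4600 nM.
Compound 3 `CCC(CC)/N=c1\c(O)c(O)\c1=N/c1ccc(C#N)cc1` in this assay gives 3340 nM.

Compound 3 holds the lowest of the two numbers, but compound 2 sits within the usual scatter of it, so no order between the two can be claimed. Compound 1 stands apart, as its value is a limit (the limit of > 30000 nM in this assay, at which 1 of the 3 values shown sits). The change from compound 3 to compound 4 `C[C@H](/N=c1\c(O)c(O)\c1=N/c1ccc(C#N)cc1)C1CCCCC1` is 1-cyclohexylethyl in place of pentan-3-yl on a double-bonded nitrogen. Going by the values given here, no measured pair shows such a change, so the step is expected to be small, probably not beyond the scatter: a 1.3-fold lower number from compound 3 to compound 4 (0.13 log units; within the scatter). Compound 4 is expected at 2500 nM, within a range from 800 nM to 8000 nM.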

Compound 4, half-maximal inhibitory concentration: > 30000 nM
Compound 4: only a limit was reported; the forecaster's own chance of this, stated with the estimate: 15%; at least 12-fold (1.07 log units) between middle value and limit.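

For the compounds shown here, replacing pentan-3-yl with 1-cyclohexylethyl on a double-bonded nitrogen gives an at least 8.9-fold higher number from compound 3 to compound 4 (0.95 log units; beyond the scatter), the first step that can be read in this set. It shows that a swap between two groups made only of carbon at this place can by itself be enough to move the result beyond the scatter. Compound 4 gives only a limit, the one already met: the limit of > 30000 nM in this assay, at which 2 of the 4 values shown sit.

The compounds shown cannot separate the ring, the added carbons and the defined stereocentre as the source of this step. Going by these compounds, how a cyclopentyl group would behave at this place also stays open.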